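A few compounds are considered here, and "the series" means these few. Any claim that something is new, unique, unknown or untested is made for them only; others in the source may bear on it.

Measured so far:
compound 1 `Cc1ccc(C(=O)N/N=C/c2ccccc2F)c(O)c1`: 362000 nM
compound 2 `Cc1ccc(C(=O)N/N=C/c2ccccc2O)c(O)c1`: 761000 nM

In an ADME assay on cells (Mus musculus, strain BALB/C) for cytotoxicity, read by MTT assay, with a stated time of 24 h (on this read-out lower numbers stand for higher toxicity in this test and higher numbers for lower toxicity in this test), compound 2 gives the higher of the two numbers. Among the measured compounds shown here, the one measured step is a 2.1-fold higher number from compound 1 to compound 2 (0.32 log units; beyond the scatter), a modest change. Compound 3 `Cc1ccc(C(=O)N/N=C/c2ccccc2[N+](=O)[O-])c(O)c1` carries nitro in place of hydroxy on an aromatic carbon. For the measured compounds named here, that step bears on it only loosely, since it shows how the hydroxy entered, not how a nitro behaves; no step with a nitro has been measured. He therefore expects at most a modest step in this assay, more likely downward, toward compound 1, or none beyond the scatter. For compound 3 the estimate is 420000 nM, within 180000 nM to 950000 nM, which is an expected step of a 1.8-fold lower number from compound 2 to compound 3 (0.26 log units; within the scatter).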

Compound 3, half-maximal cytotoxic concentration: 644000 nM
For compound 3 the middle estimate is 1.5-fold (0.19 log units) below the measured one; low and high end bracket the measured number.
By their numbers in this assay, from the lowest: compounds 1, 3 and 2 (each within the scatter of the next, the first and the last beyond it).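

On the aromatic carbon ortho to a large group in this assay, nitro in place of hydroxy gives a 1.2-fold lower number from compound 2 to compound 3 (0.07 log units; within the scatter), and nitro in place of fluoro gives a 1.8-fold higher number from compound 1 to compound 3 (0.25 log units; within the scatter). Thus nitro, with no hydrogen-bond donor, stays within the scatter of both hydroxy and fluoro, although those two differ beyond it. No evidence on the cause is available. The compounds shown leave open whether an amine or a carboxylic acid on this carbon would also stay within the scatter of these three.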